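Adding a second 2-methylphenyl to the chain carbon

The source may hold more compounds than are shown below. What is called first, only, known or untested is meant among the compounds shown, and "the series" means these compounds.

Compound 1 `C/C(=C\C(=O)Nc1ccccc1OCCCC(=O)O)c1ccc2c(ccn2Cc2ccccc2C)c1`: 69 nM
Compound 2 `COc1ccc(Cn2ccc3cc(/C(C)=C/C(=O)Nc4ccccc4OCCCC(=O)O)ccc32)cc1`: 480 nM

In an assay on Prostate gland for inhibition of steroid 5-alpha-reductase (Rattus norvegicus) (a lower number here means a stronger inhibitor, a higher number a weaker inhibitor), compound 1 gives 69 nM, while compound 2 gives 480 nM. Within the data shown here, compound 1 therefore stands at the lowest of the two numbers, and the single measured step, a 7.0-fold higher number from compound 1 to compound 2 (0.84 log units; beyond the scatter), lies beyond the scatter, so the group on the saturated chain carbon bound to the aromatic nitrogen evidently matters to this assay.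

Compound 3 `C/C(=C\C(=O)Nc1ccccc1OCCCC(=O)O)c1ccc2c(ccn2C(c2ccccc2C)c2ccccc2C)c1` differs from compound 1 by 2-methylphenyl in place of hydrogen on a saturated chain carbon bound to an aromatic carbon and an aromatic nitrogen. Among the measured compounds shown here, no measured step covers an addition of this kind: the one step available exchanges one aryl group for another at that carbon rather than adding a second one, so it bears only indirectly on compound 3. It shows that this position is sensitive, but not in which direction a second 2-methylphenyl will move the number. The estimate for compound 3 is therefore hedged, with a middle value that is expected to be modestly higher than compound 1, a step of a 2.2-fold higher number from compound 1 to compound 3 (0.34 log units; beyond the scatter), and a wide range around it. Compound 3 is expected to give 150 nM in this assay, between 40 nM and 600 nM.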

Compound 3, half-maximal inhibitory concentration: 19 nM
Beside the measured number, compound 3's estimate is 7.9-fold (0.90 log units) above it; measured number outside the range, below it.
By their numbers in this assay, from the lowest: compound 3; then compound 1; then compound 2.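

In this assay, a second aryl group on the saturated chain carbon bound to an aromatic carbon and an aromatic nitrogen lowers the number (in full, a 3.6-fold lower number from compound 1 to compound 3 (0.56 log units; beyond the scatter)), so this carbon tolerates more than one 2-methylphenyl and gains from the addition. The earlier step at this position was an exchange of one aryl group for another (a 7.0-fold higher number from compound 1 to compound 2 (0.84 log units; beyond the scatter)), which showed that the position is sensitive but gave no sign that adding a group there could lower the number. Nothing available explains this drop, and its origin remains unknown. The compounds shown leave open whether the added ring needs its methyl group at all, or whether a plain phenyl, a 4-methoxyphenyl or a small methyl group as the second substituent on that carbon would lower the number in the same way. As far as these compounds go, they also share the rest of the structure, so it remains open whether the step would hold with an amine or a longer chain in place of the carboxylic acid.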